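The source may report more compounds than this note shows. Statements on the series, on what has been measured and on what is new or still open speak of the compounds shown alone.

In an ADME assay on S9 fraction from liver (Rattus norvegicus) for metabolic stability, read by LC-MS, using NADPH, with a stated time of 30 min (on this read-out higher numbers stand for a more stable compound and lower numbers for a less stable compound), compound 1 (`CCCCCCCCc1ccc(OCC(=O)Cn2nnc(C(=O)OC)n2)cc1`) gives only a limit of the assay, < 5%. Compound 2 (`CCCCCCCCc1ccc(OCC(=O)Cn2nnnc2Cc2ccccc2)cc1`) gives 26% in this assay. For compound 3 (`CC(Oc1ccc(Oc2ccc(F)cc2)cc1)C(=O)Cn1nnc(-c2ccccc2)n1`) this assay again reports only a limit, < 5%. Compound 3 therefore stands at the limit of < 5% in this assay, at which 2 of the 3 values shown sit, so its place among the numbers shown is known only as that limit. Compound 4 (`CC(Oc1ccc(-c2ccccc2)cc1)C(=O)Cn1nnc(-c2ccccc2)n1`) differs from compound 3 by phenyl in place of 4-fluorophenoxy on an aromatic carbon. Among the measured compounds shown here, no pair differing in one place has been measured in this assay, so the size of this change can only be estimated; the expected step of a number at least 3 percentage points higher from compound 3 to compound 4 (that floor lies within the scatter) is small, probably within the usual scatter, with no clear direction. Compound 4 is estimated at 8%, with a range from 0% to 30%.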

Compound 4, percent of the compound remaining: < 5%
Compound 4: no number, only a limit (the forecaster's own chance of this, stated with the estimate: 45%); at least 3 percentage points between middle value and limit.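

Compound 3 and compound 4 both give only a limit in this assay, so no step between them can be read: the limit of < 5% in this assay, at which 3 of the 4 values shown sit.

The compounds shown leave open whether phenyl in place of 4-fluorophenoxy changes the percent remaining at all.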